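Sulfonyl series on the shared core: growing the sulfonyl substituent

The compounds below may be only part of what the source reports. "The series", "measured", "known", "first", "only" and "open" are said of these compounds alone.

Measured so far, in a functional assay on HCC1806 cells (Homo sapiens) for inhibition, read by sulforhodamine B assay, tested at 10 uM; a lower number here means less inhibition, a higher number more inhibition at the concentration tested (going by the name of the read-out):
compound 1 `CN1CCN(c2ccc(C3=NN(C(=O)CCCl)C(c4ccc(N(C)C)cc4)C3)cc2)CC1` gives 1.7%
compound 2 `CN1CCN(c2ccc(C3=NN(C(=O)/C=C/c4ccccc4)C(c4ccc(N(C)C)cc4)C3)cc2)CC1` gives 71%
compound 3 `CN1CCN(c2ccc(C3=NN(S(C)(=O)=O)C(c4ccc(N(C)C)cc4)C3)cc2)CC1` gives -18.5%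

Compound 3 sits lowest of the three; its nearest neighbour is compound 1, with a number 20.2 percentage points lower from compound 1 to compound 3 (beyond the scatter), and the far one is compound 2, with a number 89.5 percentage points lower from compound 2 to compound 3 (beyond the scatter). Compound 4 `CN1CCN(c2ccc(C3=NN(S(=O)(=O)c4ccc(C(F)(F)F)cc4)C(c4ccc(N(C)C)cc4)C3)cc2)CC1` differs from compound 3 in one place: 4-(trifluoromethyl)phenyl in place of methyl on a sulfonyl sulfur. For the measured compounds named here, no measured step alters a sulfonyl substituent, so the bearing is indirect. Going by the values given here, the only step that brings in an aromatic ring is a number 69.3 percentage points higher from compound 1 to compound 2 (beyond the scatter), a large rise, but on a carbonyl rather than a sulfonyl. A rise of uncertain size is therefore expected for compound 4, a number 30.5 percentage points higher from compound 3 to compound 4 (beyond the scatter). Compound 4 is estimated at 12% in this assay, between -15% and 45%.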

Compound 4, a percentage reported as inhibition, at one concentration (the size of the read-out at that concentration, not a potency): 27%
For compound 4 the middle estimate is 15 percentage points below the measured one, and the stated range covers the measured number.
By their numbers in this assay, from the lowest: compound 3; then compound 1; then compound 4; then compound 2.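

In this assay the substituent on the sulfonyl sulfur matters in its own right: 4-(trifluoromethyl)phenyl in place of methyl gives a number 45.5 percentage points higher from compound 3 to compound 4 (beyond the scatter). An aromatic ring on the sulfonyl therefore goes with a higher number, as it did on the carbonyl, yet compound 4 at 27% still stands under compound 2 at 71%. No measurement here accounts for the rise. The compounds shown leave open whether the phenyl ring or the trifluoromethyl group carries the gain, which an unsubstituted phenyl on the sulfonyl sulfur would separate.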